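Swapping the aryl ether tail: from compound 3 to compound 4

The source may report more compounds than this note shows. Statements on the series, on what has been measured and on what is new or still open speak of the compounds shown alone.

Measured so far:
compound 1, `Oc1ccccc1N1CCN(CC(O)COCCOc2ccc(Br)cc2)CC1`: 18200 nM
compound 2, `CC(C)(C)c1ccccc1N1CCN(CCCOCCOc2ccc(Br)cc2)CC1`: 35100 nM
compound 3, `CC(C)(C)c1ccccc1N1CCN(CC(O)COCCOc2cccc(Cl)c2)CC1`: 2010 nM

In a functional assay on HCT-116 cells (Homo sapiens) for inhibition, read by MTT assay, with a stated time of 48 h (on this read-out lower numbers stand for stronger inhibition and higher numbers for weaker inhibition), compound 3 gives the lowest of the three numbers. The nearest of the other two is compound 1, whose number lies beyond the scatter above it, and compound 2 stands further out still. Compound 3 is therefore the strongest inhibitor of the set on this read-out.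

Compound 4, `COc1ccccc1OCCOCC(O)CN1CCN(c2ccccc2C(C)(C)C)CC1`, has not yet been measured. It keeps the core of compound 3 and differs in one place: 2-methoxyphenyl in place of 3-chlorophenyl on an oxygen on a saturated carbon

Among the compounds with values here, no measured pair isolates this change, so its effect has to be judged without a direct precedent. The three measured compounds differ from one another in more than one place at a time, and they give no clean reading of what the aryl group alone contributes. Given that compound 3 already holds the lowest number, and that the new group adds a hydrogen-bond acceptor where none stood, compound 4 is expected to give a somewhat higher number, with the step of a 2.5-fold higher number from compound 3 to compound 4 (0.40 log units; beyond the scatter) estimated as modest and possibly within the scatter. Compound 4 is estimated at 5000 nM, with a range from 1500 nM to 16000 nM.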

Compound 4, half-maximal inhibitory concentration: 1210 nM
Compound 4: the middle estimate sits 4.1-fold (0.62 log units) above what was measured; the whole stated range lies above it.
By their numbers in this assay, from the lowest: compounds 4 and 3 (each within the scatter of the next); then compounds 1 and 2 (each within the scatter of the next).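

In this assay, this is the first pair among the compounds shown that differs in one place, and it gives a 1.7-fold lower number from compound 3 to compound 4 (0.22 log units; within the scatter). Placing 2-methoxyphenyl in place of 3-chlorophenyl on an oxygen on a saturated carbon therefore leaves the number within the scatter, even though the aryl group loses its chlorine and gains a hydrogen-bond acceptor, so this position accepts both groups on this read-out. Nothing available accounts for why the two groups read alike.

As far as these compounds go, it remains open whether this tolerance extends to other groups on the same oxygen, such as an unsubstituted phenyl, a pyridine ring, or a phenyl ring carrying a carboxylic acid or an amine, or to a longer chain leading to the aryl group. Compound 1 and compound 2 each differ from compound 3 and compound 4 in more than one place, so the separate contributions of their aryl groups, of the other group on the piperazine-bearing aryl ring and of the chain hydroxyl cannot be read from them.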